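A few compounds are considered here, and "the series" means these few. Any claim that something is new, unique, unknown or untested is made for them only; others in the source may bear on it.

Measured in an ADME assay on MT4 cells (Homo sapiens) for cytotoxicity, read by spectrophotometry, with a stated time of 5 days; on this read-out higher numbers stand for lower toxicity in this test and lower numbers for higher toxicity in this test:
- compound 1 `CONC(=S)N/N=C1\C(=O)N(CN2CCN(c3ccc(Cl)cc3)CC2)c2ccc(Cl)cc21`: 229000 nM
- compound 2 `COc1ccc(N2CCN(CN3C(=O)/C(=N\NC(=S)NO)c4cc(Cl)ccc43)CC2)cc1`: 279000 nM
- compound 3 `O=C1/C(=N\NC(=S)NO)c2cc(Cl)ccc2N1CN1CCN(c2ccccc2)CC1`: 273000 nM

Compound 3, at 273000 nM, lies within the scatter of both other compounds, so the three numbers in this assay give no real ranking. Compound 4 `O=C1/C(=N\NC(=S)NO)c2cc(Cl)ccc2N1CN1CCN(c2ccc(Cl)cc2)CC1`, not yet measured, differs from compound 3 in one place: chloro in place of hydrogen on an aromatic carbon. This is chloro in place of hydrogen on an aromatic carbon, or phenyl to 4-chlorophenyl.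

Going by the values given here, only one measured step changes a substituent on this aromatic ring: a 1.0-fold lower number from compound 2 to compound 3 (0.01 log units; within the scatter). It replaces methoxy with hydrogen rather than introducing chloro, so it bears on the change only indirectly. Compound 1 differs from compound 4 elsewhere but also carries the 4-chlorophenyl group, and compound 1 gives 229000 nM, which is within the scatter of the value for compound 3. Neither observation points to a step beyond the scatter, and none is expected here in this assay. The expected change is small and without a meaningful direction: a 1.1-fold lower number from compound 3 to compound 4 (0.02 log units; within the scatter). For compound 4, the estimated value is 260000 nM, with an expected range of 160000 nM to 400000 nM.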

Compound 4, half-maximal cytotoxic concentration: 268000 nM
Beside the measured number, compound 4's estimate is 1.0-fold (0.01 log units) below it; the range from low to high includes it.
By their numbers in this assay, from the lowest: compounds 1, 4, 3 and 2 (each within the scatter of the next).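

In this assay, chloro in place of hydrogen on an aromatic carbon para to a large group is a step within the scatter (a 1.0-fold lower number from compound 3 to compound 4 (0.01 log units; within the scatter)), and chloro in place of methoxy at that same carbon is too (a 1.0-fold lower number from compound 2 to compound 4 (0.02 log units; within the scatter)). The earlier compounds shown here had compared only methoxy and hydrogen at this place; now hydrogen, methoxy and chloro can all be compared there, and the three cannot be told apart in this test. With the 4-chlorophenyl group kept, hydrogen in place of methyl on an oxygen also stays within the scatter (a 1.2-fold higher number from compound 1 to compound 4 (0.07 log units; within the scatter)), so neither of the two places varied among these compounds has yet given a step beyond it, and nothing available accounts for this.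

The compounds shown leave open whether a quite different group at this ring carbon, such as an amine or a carboxylic acid, would give a step beyond the scatter. They also leave open whether a longer chain on that oxygen, in place of hydrogen or methyl, would do so.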